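The source may hold more compounds than are shown below. What is called first, only, known or untested is meant among the compounds shown, and "the series" means these compounds.

In a functional assay on DU-145 cells (Homo sapiens) for inhibition, read by trypan blue exclusion, with a stated time of 96 h (on this read-out lower numbers stand for stronger inhibition of growth and higher numbers for weaker inhibition of growth), compound 1 (`O=C(/C(=C\c1c(O)cc(O)cc1O)S(=O)(=O)c1ccccc1Br)c1ccc(Cl)cc1`) gives 50000 nM and compound 2 (`Cc1ccsc1/C=C(/SCc1ccc(Cl)c(Cl)c1)C(=O)c1ccc(Cl)cc1`) gives 50000 nM as measured values. Compound 3 (`O=C(/C(=C\c1c(O)cc(O)cc1O)SCc1ccc(Cl)cc1)c1ccc(Cl)cc1`) stands at > 100000 nM as a limit of the assay, not a number. Compound 4 (`O=C(/C(=C\c1c(O)cc(O)cc1O)SCc1ccc(Cl)c(Cl)c1)c1ccc(Cl)cc1`) differs from it by chloro in place of hydrogen on an aromatic carbon, turning 4-chlorobenzyl into 3,4-dichlorobenzyl. Going by the values given here, the one measured step (an at least 2.0-fold higher number from compound 1 to compound 3 (0.30 log units; that floor lies within the scatter)) exchanges the whole group on the chain and says little about this chloro. Compound 2 already carries (3,4-dichlorobenzyl)sulfanyl on a different remainder. A small move toward a lower number is therefore expected, and the estimated step is an at least 1.4-fold lower number from compound 3 to compound 4 (0.15 log units; that floor lies within the scatter) in size. For compound 4 the expected value is 70000 nM with an estimated range from 30000 nM to 150000 nM as its bounds.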

Compound 4, concentration for 50% growth inhibition: 25000 nM
Estimate against measurement, compound 4: 2.8-fold (0.45 log units) above, and the stated range ends above it.
By their numbers in this assay, from the lowest: compounds 4, 1 and 2 (each within the scatter of the next). At a limit, above all of these: compound 3.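

Turning 4-chlorobenzyl into 3,4-dichlorobenzyl gives an at least 4.0-fold lower number from compound 3 to compound 4 (0.60 log units; beyond the scatter), the only step shown that clears the scatter, so this one chloro matters more than the earlier exchange of the whole group suggested. Compound 3 stands at a limit and not a number, so that step has only a floor: the limit of > 100000 nM in this assay, at which 1 of the 4 values shown sits. The exchanges in a 2.0-fold lower number from compound 2 to compound 4 (0.30 log units; within the scatter) and a 2.0-fold lower number from compound 1 to compound 4 (0.30 log units; within the scatter) leave compound 4 within the scatter of both partners.

Going by these compounds, the true size of the chloro step stays open. So does whether a methoxy group or an amine at this place would do the same.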